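This account rests on a few compounds, and the source may have more. Where it says the series, first, only, none or still open, it means among the compounds named here.

Three compounds built on one shared core have been examined in a physicochemical assay for solubility; on this read-out lower numbers stand for lower solubility and higher numbers for higher solubility. Compound 1 `CNC(=O)c1cc(C(=O)NC(C)C)cn(Cc2ccccc2)c1=O` reaches a limit of the assay, >= 136 ug/mL. Compound 3 `CNC(=O)c1cc(C(=O)NC2CCC2)cn(Cc2ccccn2)c1=O` likewise reaches a limit of the assay, >= 103 ug/mL. Compound 2 `CNC(=O)c1cc(C(=O)NC2CC2)cn(Cc2nccc3[nH]ccc23)c1=O` is the only one of the three to return a number rather than a limit, and in this assay compound 2 gives 73 ug/mL. The unmeasured compound 4 `CNC(=O)c1cc(C(=O)NC2CC2)cn(CC2CCOCC2)c1=O` differs from compound 2 by a group of 6 heavy atoms (5 carbon, 1 oxygen; one six-membered non-aromatic ring with 1 hetero atom) in place of a group of 9 heavy atoms (7 carbon, 2 nitrogen; one five-membered aromatic ring with 1 hetero atom, one six-membered aromatic ring with 1 hetero atom), on a saturated chain carbon bound to an aromatic nitrogen. Going by the values given here, no step between measured compounds is available to calibrate this change; the expectation rests on the structures alone. Compound 4 is expected to be more soluble than compound 2, with the step of a 2.2-fold higher number from compound 2 to compound 4 (0.34 log units; beyond the scatter) estimated to exceed the usual scatter. Compound 4 is estimated at 160 ug/mL, within a range of 60 ug/mL to 400 ug/mL.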

Compound 4, solubility: >= 165 ug/mL
Compound 4 was reported as a limit (the forecaster's own chance of this, stated with the estimate: 40%); middle value at least 1.0-fold (0.01 log units) away from the limit.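

Putting oxan-4-yl in place of the group of 9 heavy atoms, on a saturated chain carbon bound to an aromatic nitrogen, gives an at least 2.2-fold higher number from compound 2 to compound 4 (0.35 log units; beyond the scatter) in this assay. Going by these compounds alone, this is the first change in a single place that can be read, and it lies beyond the usual scatter. Its full size stays open because compound 4 stands at a limit of the assay: the limit of >= 165 ug/mL in this assay, at which 1 of the 4 values shown sits.

The compounds shown leave open how a piperidin-4-yl group or a carboxylic acid would read at this place. They also leave open whether oxan-4-yl gives a similar step with another amide on the shared core.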